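Swapping the Propyl Group for Bromine on an Imidazoline Ether

The source may hold more compounds than are shown below. What is called first, only, known or untested is meant among the compounds shown, and "the series" means these compounds.

Compound 3 `CCCc1ccccc1OCC1=NCCN1`: 155 nM
Compound 1 `c1ccc(OCC2=NCCN2)c(CC2CC2)c1`: 234 nM
Compound 2 `c1ccc(OC2CC2)c(OCC2=NCCN2)c1`: 1000 nM

In an assay on isolated protein for agonist activity at Alpha-2C adrenergic receptor (Homo sapiens) (on this read-out lower numbers stand for an effect already at smaller amounts and higher numbers for an effect only at larger amounts of compound), compound 3 and compound 1 lie within the scatter of one another, as a 1.5-fold lower number from compound 1 to compound 3 (0.18 log units; within the scatter) shows, while compound 2 gives a higher number than both, as a 6.5-fold lower number from compound 2 to compound 3 (0.81 log units; beyond the scatter) shows. Compound 4 `Brc1ccccc1OCC1=NCCN1` differs from compound 3 by bromo in place of propyl on an aromatic carbon. Among the compounds with values here, no measured step exchanges a carbon chain for a halogen at this carbon. The step of a 4.3-fold higher number from compound 1 to compound 2 (0.63 log units; beyond the scatter) shows that a change at this carbon can move the number beyond the scatter, whereas a 1.5-fold lower number from compound 1 to compound 3 (0.18 log units; within the scatter) shows a change there that stays within it. For compound 4 a step of a 1.9-fold higher number from compound 3 to compound 4 (0.29 log units; within the scatter) is expected. Compound 4 is estimated at 300 nM, with a range from 100 nM to 1000 nM.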

Compound 4, half-maximal effective concentration: 97.7 nM
Compound 4: the middle estimate sits 3.1-fold (0.49 log units) above what was measured; the whole stated range lies above it.
By their numbers in this assay, from the lowest: compounds 4, 3 and 1 (each within the scatter of the next, the first and the last beyond it); then compound 2.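

In this assay, swapping the propyl chain for a single bromo atom gives a 1.6-fold lower number from compound 3 to compound 4 (0.20 log units; within the scatter), so a carbon chain is not needed at this aromatic carbon to keep the number low. Bromo also compares well with the other two groups here, with a 2.4-fold lower number from compound 1 to compound 4 (0.38 log units; beyond the scatter) against cyclopropylmethyl and a 10-fold lower number from compound 2 to compound 4 (1.01 log units; beyond the scatter) against cyclopropyloxy, the largest step in this set. Nothing available explains why these steps take the sizes they do.

As far as these compounds go, whether chlorine, an amine or a carboxylic acid at this carbon would match bromo remains open. So does whether bromo would give similar numbers on another carbon of the ring.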